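The source may hold more compounds than are shown below. What is called first, only, known or untested is meant among the compounds shown, and "the series" means these compounds.

Measured so far:
Compound 1 `O=C(CCCCC1CCSS1)NCc1cn(CCCOc2ccc3cc(C(=O)O)c(=O)oc3c2)nn1` — in a functional assay on PC-12 cells (Rattus norvegicus) for cytotoxicity, read by MTT assay, with stated times of 3 h and 2 h, tested at 50 uM (a lower number here means a weaker effect, a higher number a stronger effect of the compound at the concentration tested), compound 1 gives 73.5%.
Compound 2 `COc1ccc(-c2cc3ccc(OCCCn4cc(CNC(=O)CCCCC5CCSS5)nn4)cc3oc2=O)cc1` — compound 2 gives 65.7%.
Compound 3 `O=C(CCCCC1CCSS1)NCc1cn(CCCCOc2ccc3ccc(=O)oc3c2)nn1` — compound 3 gives 75.8%.

Compound 3 holds the highest of the three numbers, with compound 1 within the scatter of it and only compound 2 beyond the scatter below it. Compound 4 `O=C(CCCCC1CCSS1)NCc1cn(CCCCOc2ccc3cc(-c4ccc(Br)cc4)c(=O)oc3c2)nn1` differs from compound 3 by 4-bromophenyl in place of hydrogen on an aromatic carbon. Among the compounds with values here, the one measured step at that aromatic carbon is a number 7.8 percentage points lower from compound 1 to compound 2 (within the scatter), where an aryl group also enters; it shifts nothing beyond the scatter. On that basis a step within the scatter is expected in this assay, if anything slightly downward, as a number 7.8 percentage points lower from compound 3 to compound 4 (within the scatter). Compound 4 is therefore estimated at 68%, with a range from 55% to 80%.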

Compound 4, a percentage reported as activity, at one concentration (the size of the read-out at that concentration, not a potency): 47.6%
Compound 4: middle estimate off by 20.4 percentage points, on the high side; measured number below the stated range.
By their numbers in this assay, from the lowest: compound 4; then compounds 2, 1 and 3 (each within the scatter of the next, the first and the last beyond it).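

In this assay the entry of 4-bromophenyl in place of hydrogen gives a number 28.2 percentage points lower from compound 3 to compound 4 (beyond the scatter) at this aromatic carbon. The earlier step, a number 7.8 percentage points lower from compound 1 to compound 2 (within the scatter), replaced carboxy rather than hydrogen and stayed inside the scatter, so this position can respond to an aryl group beyond the scatter. No measured evidence here explains the size of the new step.

The compounds shown leave open whether the bromine or the phenyl ring carries this step. As far as these compounds go, how a plain phenyl or a 4-aminophenyl group would read at this carbon also remains open.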